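Aryl urea replacement on the semicarbazide tail

The source may report more compounds than this note shows. Statements on the series, on what has been measured and on what is new or still open speak of the compounds shown alone.

Measured compounds in a functional assay on MCF7 cells (Homo sapiens) for inhibition, read by MTT assay, with a stated time of 4 days; on this read-out higher numbers stand for weaker inhibition and lower numbers for stronger inhibition:
- compound 1, `CCOC(=O)NC(c1ccccc1)c1ccc(Cl)cc1`, gives > 100000 nM; this is a limit of the assay, not a number.
- compound 2, `COc1cc(NC(C)CCCNC(=O)NNC(=O)N(CCO)CCO)c2ncccc2c1`, gives 29000 nM.
- compound 3, `COc1cc(NC(C)CCCNC(=O)Nc2ccc(Cl)c(C(F)(F)F)c2)c2ncccc2c1`, gives 4000 nM.

Compound 2 holds the highest number of the two measured values in this assay; the nearest is compound 3, and the remaining entry for compound 1 is a limit, as noted in the limit of > 100000 nM in this assay, at which 1 of the 3 values shown sits.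

Compound 4, `COc1cc(NC(C)CCCNC(=O)NNC(=O)Nc2ccc(Cl)c(C(F)(F)F)c2)c2ncccc2c1`, is not yet measured. It differs from compound 2 as follows: (4-chloro-3-(trifluoromethyl)phenyl)amino in place of bis(2-hydroxyethyl)amino on a carbonyl carbon.

Among the measured compounds shown here, the one measured step that bears on this change is a 7.3-fold lower number from compound 2 to compound 3 (0.86 log units; beyond the scatter), where the same aryl group entered but the whole carbamoylamino linker was dropped rather than kept. Compound 4 keeps that linker, so the change is smaller than the measured one, and a step in the same direction but of lesser size is expected; the estimated step is a 2.9-fold lower number from compound 2 to compound 4 (0.46 log units; beyond the scatter).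

For compound 4 the expected value in this assay is 10000 nM, with a likely range from 3000 nM to 40000 nM.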

Compound 4, half-maximal inhibitory concentration: 2000 nM
Compound 4: middle estimate off by 5.0-fold (0.70 log units), on the high side, and the stated range ends above it.
By their numbers in this assay, from the lowest: compounds 4 and 3 (each within the scatter of the next); then compound 2. At a limit, above all of these: compound 1.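

With the carbamoylamino linker kept, the exchange of bis(2-hydroxyethyl)amino for (4-chloro-3-(trifluoromethyl)phenyl)amino on a carbonyl carbon in this assay is enough on its own for a 15-fold lower number from compound 2 to compound 4 (1.16 log units; beyond the scatter) and so separates the aryl group from the loss of the linker, which the earlier step of a 7.3-fold lower number from compound 2 to compound 3 (0.86 log units; beyond the scatter) could not do. With this aryl group present, the linker makes no difference that can be told: compound 3 at 4000 nM and compound 4 at 2000 nM lie within the scatter of each other. Nothing at hand accounts for the size of the step.

On these data alone, whether plain phenylamino, without the chlorine and the trifluoromethyl, would give a similar step on this carbonyl carbon remains open. Also open, as far as these compounds go, is how a non-aromatic cyclohexylamino group would compare there.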